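This account rests on a few compounds, and the source may have more. Where it says the series, first, only, none or still open, it means among the compounds named here.

Measured compounds in a functional assay on HeLa cells (Homo sapiens) for inhibition, read by cell counting, with a stated time of 4 days; on this read-out higher numbers stand for weaker inhibition and lower numbers for stronger inhibition:
compound 1, `C=C(Br)C(=O)Nc1cccc(-c2cn3nc(-c4ccc(OCC)cc4)sc3n2)c1`: 1100 nM
compound 2, `COc1ccc(-c2csc3nc(-c4cccc(N)c4)cn23)cc1`: 19000 nM

Of the two numbers measured in this assay, compound 1 stands lowest; compound 2 sits at the higher value, and the gap between the two lies beyond the usual scatter. The two compounds do not share a common core drawn in the same way, so nothing in the measured pair tracks a single substituent change.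

Compound 3, `C=C(Br)C(=O)Nc1cccc(-c2cn3nc(Cc4ccccc4)sc3n2)c1`, keeps the core and the bromoacrylamide of compound 1 and changes one group: benzyl in place of 4-ethoxyphenyl on an aromatic carbon. Going by the values given here, no measured pair shows this replacement, so its effect must be guessed from compound 1 alone. A step of modest size toward weaker inhibition seems the more likely outcome, though one within the scatter cannot be excluded. Compound 3 is accordingly expected to give about 2500 nM in this assay, with a plausible range of 800 nM to 8000 nM. This estimate corresponds to an expected step of a 2.3-fold higher number from compound 1 to compound 3 (0.36 log units; beyond the scatter).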

Compound 3, half-maximal inhibitory concentration: 4500 nM
Compound 3: middle estimate off by 1.8-fold (0.26 log units), on the low side, within the range that was stated.
By their numbers in this assay, from the lowest: compound 1; then compound 3; then compound 2.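

In this assay, benzyl in place of 4-ethoxyphenyl on the aromatic carbon next to the ring sulfur gives a 4.1-fold higher number from compound 1 to compound 3 (0.61 log units; beyond the scatter), a modest step. This pair is the only one shown that differs in one place, and it indicates that the number at this position responds to the group carried there while the shared core and the bromoacrylamide stay fixed. No measurement at hand gives a reason for this step.

The change combines two differences, the extra carbon joining the aromatic ring to the core and the absence of the ethoxy group, and this single pair does not separate them. As far as these compounds go, how a plain phenyl, a 4-aminophenyl or a 4-carboxyphenyl group would read at this position remains open.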